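Azole exchange at the chain carbon: compound 3

The source may report more compounds than this note shows. Statements on the series, on what has been measured and on what is new or still open speak of the compounds shown alone.

Compound 1 `Cn1cnc(CN2CCN(c3cccc4[nH]c(-c5ccc(C(C)(C)C)cc5)nc34)CC2)c1`: 33 nM
Compound 2 `Cc1nc(C)c(CN2CCN(c3cccc4[nH]c(-c5ccc(C(C)(C)C)cc5)nc34)CC2)s1`: 27 nM

In an assay on isolated protein for displacement of a labelled ligand from Gonadotropin-releasing hormone receptor (Homo sapiens) (on this read-out lower numbers stand for stronger inhibition and higher numbers for weaker inhibition), compound 2 stands at the lowest of the two numbers, yet a 1.2-fold lower number from compound 1 to compound 2 (0.09 log units; within the scatter) lies within the scatter, so the two compounds cannot be told apart. Compound 3 `CCn1cc(CN2CCN(c3cccc4[nH]c(-c5ccc(C(C)(C)C)cc5)nc34)CC2)nc1C` is not yet measured; it carries 1-ethyl-2-methyl-1H-imidazol-4-yl in place of 2,4-dimethyl-1,3-thiazol-5-yl on a saturated chain carbon bound to an amine nitrogen in a ring. Among the measured compounds shown here, the only step that bears on this, a 1.2-fold lower number from compound 1 to compound 2 (0.09 log units; within the scatter), exchanged one five-membered aromatic ring with 2 hetero atoms for another and moved nothing beyond the scatter. The same outcome is expected here, no step beyond the scatter, a 1.1-fold higher number from compound 2 to compound 3 (0.05 log units; within the scatter). Compound 3 is estimated at 30 nM, within 12 nM to 75 nM.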

Compound 3, half-maximal inhibitory concentration: 10 nM
Beside the measured number, compound 3's estimate is 3.0-fold (0.48 log units) above it; the whole stated range lies above it.
By their numbers in this assay, from the lowest: compound 3; then compounds 2 and 1 (each within the scatter of the next).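

In this assay the exchange on a saturated chain carbon bound to an amine nitrogen in a ring now moves the number: a 2.7-fold lower number from compound 2 to compound 3 (0.43 log units; beyond the scatter) and a 3.3-fold lower number from compound 1 to compound 3 (0.52 log units; beyond the scatter) both lie beyond the scatter. The ring type alone does not settle the value, since 1-methyl-1H-imidazol-4-yl and 1-ethyl-2-methyl-1H-imidazol-4-yl are both imidazoles yet differ by the second step. No measurement on hand accounts for either step.

From the compounds shown here alone, whether the ethyl or the added methyl carries the step stays open, since the two change together from compound 1 to compound 3. Going by these compounds, how a longer chain such as propyl, or a terminal amine, would read at that ring nitrogen is also open.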